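Changing the Amide Substituent: Expected Cytotoxicity of Compound 4

The compounds below may be only part of what the source reports. "The series", "measured", "known", "first", "only" and "open" are said of these compounds alone.

Compound 1 `Cc1ccccc1NC(=O)CCC(=O)OCCCCCCSc1ccc([N+](=O)[O-])c2nonc12` gives 1410 nM in an ADME assay on HUVEC cells (Homo sapiens) for cytotoxicity, read by MTT assay, with a stated time of 72 h; a lower number here means a stronger inhibitor, a higher number a weaker inhibitor.
Compound 2 `COc1ccccc1NC(=O)CCC(=O)OCCCCCCSc1ccc([N+](=O)[O-])c2nonc12` gives 1610 nM in this assay.
Compound 3 `O=C(CCC(=O)OCCCCCCSc1ccc([N+](=O)[O-])c2nonc12)Nc1ccc(C(F)(F)F)cc1` gives 1390 nM in this assay.

Compound 2 has the highest number of the three, yet its separation from the others is small: a 1.1-fold higher number from compound 1 to compound 2 (0.06 log units; within the scatter) and a 1.2-fold lower number from compound 2 to compound 3 (0.06 log units; within the scatter), and likewise a 1.0-fold lower number from compound 1 to compound 3 (0.01 log units; within the scatter). All three measured compounds therefore sit together within the scatter of this assay, and none can be called stronger or weaker than another.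

Compound 4 `CCN(CC)CCCNC(=O)CCC(=O)OCCCCCCSc1ccc([N+](=O)[O-])c2nonc12` has not yet been measured. It differs from compound 2 in one place: 3-(diethylamino)propyl in place of 2-methoxyphenyl on an amide-type nitrogen. The three measured steps all exchange one substituted phenyl for another on the same amide-type nitrogen, and each stayed within the scatter. Going by the values given here, none of them replaces the ring with a chain, so no step bears directly on this change; they show only that varying the group on this nitrogen has so far left the number essentially unchanged.

On that basis compound 4 is expected to give a number close to that of compound 2, with a 1.1-fold higher number from compound 2 to compound 4 (0.05 log units; within the scatter) expected to stay within or near the scatter, and the estimate for compound 4 is 1800 nM, with a range from 800 nM to 4500 nM.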

Compound 4, half-maximal inhibitory concentration: 2950 nM
For compound 4 the middle estimate is 1.6-fold (0.21 log units) below the measured one; measured number inside the range.
By their numbers in this assay, from the lowest: compounds 3, 1, 2 and 4 (each within the scatter of the next, the first and the last beyond it).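

In this assay, going by these compounds alone, the group on this amide-type nitrogen proved able to move the number after all: the three substituted phenyl groups had stayed within the scatter of one another, whereas 3-(diethylamino)propyl, the first group here without a ring, lies beyond the scatter against two of them (a 2.1-fold higher number from compound 1 to compound 4 (0.32 log units; beyond the scatter); a 2.1-fold higher number from compound 3 to compound 4 (0.33 log units; beyond the scatter)). The shift is modest and does not hold against all three phenyl compounds, since the step from the 2-methoxyphenyl compound stays within the scatter (a 1.8-fold higher number from compound 2 to compound 4 (0.26 log units; within the scatter)), so compound 4 cannot be set apart from compound 2, and the position tolerates this exchange of a ring for a chain with little more than a small rise in the number. Nothing is available that would explain this shift.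

The compounds shown leave open whether the shift goes with the loss of the phenyl ring or with the amine at the end of the chain, which a plain alkyl chain such as butyl, or a phenyl ring carrying a diethylamino group, would help to separate. They also leave open how a carboxylic acid or a morpholine at the end of the same propyl chain would read in this assay.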